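Valine ester in place of acetate on a carbapenem thioether

The source may hold more compounds than are shown below. What is called first, only, known or untested is meant among the compounds shown, and "the series" means these compounds.

Measured so far:
compound 1, `COC(=O)C1=C(S[C@@H]2CN[C@H](C(=O)Nc3cccc(C(=O)OC)c3)C2)[C@H](C)[C@@H]2[C@@H]([C@@H](C)O)C(=O)N12` — 403 ng.h/mL
compound 2, `CCOC(=O)C1=C(S[C@@H]2CN[C@H](C(=O)Nc3cccc(C(=O)OCC)c3)C2)[C@H](C)[C@@H]2[C@@H]([C@@H](C)OC(C)=O)C(=O)N12` — < 57.4 ng.h/mL

In an ADME assay on the whole organism (plasma, strain Beagle) for pharmacokinetics, with Canis familiaris (Canis lupus familiaris) as the target, read by LC-MS, with a stated time of 8 h, at a dose of 10 mg/kg by the intraduodenal route (on this read-out lower numbers stand for lower exposure and higher numbers for higher exposure at the dose given), compound 1 gives 403 ng.h/mL. Compound 2 gives only a limit in this assay, < 57.4 ng.h/mL, so its exposure is known only as the limit of < 57.4 ng.h/mL in this assay, at which 1 of the 2 values shown sits. Compound 3, `CCOC(=O)C1=C(S[C@@H]2CN[C@H](C(=O)Nc3cccc(C(=O)OCC)c3)C2)[C@H](C)[C@@H]2[C@@H]([C@@H](C)OC(=O)[C@@H](N)C(C)C)C(=O)N12`, differs from compound 2 by 1-amino-2-methylpropyl in place of methyl on a carbonyl carbon; the same change read one bond further out is acetoxy to ((1-amino-2-methylpropyl)carbonyl)oxy. Among the measured compounds shown here, with compound 2 at a limit, no measured step fixes the size of this change. Compound 3 is expected to show a step of an at least 2.6-fold higher number from compound 2 to compound 3 (0.41 log units; beyond the scatter) in this assay, an increase that may still sit within the scatter. The exposure of compound 3 is estimated at 150 ng.h/mL, between 30 ng.h/mL and 800 ng.h/mL.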

Compound 3, area under the concentration-time curve: "below limit of detection" (no number reported)
Compound 3 has no reported number here; no gap can be computed for the estimate.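

No step can be read between compound 2 and compound 3: compound 3 has no reported number, and compound 2 has only a limit. The compounds shown leave open how exposure changes with 1-amino-2-methylpropyl in place of methyl.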